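The source may report more compounds than this note shows. Statements on the series, on what has been measured and on what is new or still open speak of the compounds shown alone.

In a physicochemical assay for solubility (on this read-out higher numbers stand for higher solubility and lower numbers for lower solubility), compound 1 (`O=C(NC[C@H](NS(=O)(=O)c1cccs1)C(=O)O)c1ccc(N2CCC[C@H](NC3=NCCCN3)C2)cc1`) gives 3300 ug/mL and compound 2 (`O=C(NC[C@H](NS(=O)(=O)c1ccccc1)C(=O)O)c1ccc(N2CCC[C@H](NC3=NCCCN3)C2)cc1F`) gives 2800 ug/mL and the two values lie within the scatter of each other. Compound 3 (`O=C(NC[C@H](NS(=O)(=O)c1ccccc1)C(=O)O)c1ccc(N2CCC[C@H](NC3=NCCCN3)C2)cc1`) departs from compound 2 by a single change, hydrogen in place of fluoro on an aromatic carbon with hydrogen in place of fluoro on an aromatic carbon. For the measured compounds named here, no measured pair of compounds shows this change alone, so the data offer no direct guide to its size. The expected move is a 1.1-fold higher number from compound 2 to compound 3 (0.03 log units; within the scatter) and it is estimated to stay within the scatter. For compound 3 the estimated value is 3000 ug/mL with an expected range from 1500 ug/mL to 5500 ug/mL in this measurement.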

Compound 3, solubility: 3500 ug/mL
The estimate for compound 3 lay 1.2-fold (0.07 log units) below the measured number, and the stated range covers the measured number.
By their numbers in this assay, from the lowest: compounds 2, 1 and 3 (each within the scatter of the next).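

In this assay, hydrogen in place of fluoro on an aromatic carbon, ortho to a large group and meta to a large group, gives a 1.3-fold higher number from compound 2 to compound 3 (0.10 log units; within the scatter), so the fluoro group at this position makes no difference beyond the scatter. Phenyl in place of thiophen-2-yl on the sulfonyl sulfur gives a 1.1-fold higher number from compound 1 to compound 3 (0.03 log units; within the scatter), so that exchange also stays within the scatter. Nothing available gives a reason for either result. The compounds shown leave open whether a methoxy group or an amine on this aromatic carbon would give a step beyond the scatter. They also leave open whether fluoro has the same small effect when thiophen-2-yl sits on the sulfonyl sulfur.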